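Ketone to amide on the shared dihydropyrimidinone core

The source may hold more compounds than are shown below. What is called first, only, known or untested is meant among the compounds shown, and "the series" means these compounds.

Measured so far:
compound 1 `CCCC(=O)C1=C(C)NC(=O)NC1c1ccco1` — 1%
compound 2 `CCCC(=O)C1=C(C)NC(=O)NC1c1cccs1` — 2%

Both compounds were run in an assay on membranes from CHO cells for displacement of a labelled ligand from adenosine receptor A1 (Homo sapiens), read by scintillation counting, with a stated time of 60 min, tested at 1 uM; on this read-out higher numbers stand for more inhibition at the one concentration tested (going by the name of the read-out) and lower numbers for less inhibition. Going by the values given here, compound 1 gives 1% and compound 2 gives 2%; the single step between them, a number 1 percentage points higher from compound 1 to compound 2 (within the scatter), is within the scatter, so the two numbers in this assay are level. Where compound 2 stands is simply alongside compound 1, both near the bottom of the scale of this assay.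

Compound 3 `CC1=C(C(=O)NC(C)C)C(c2cccs2)NC(=O)N1` differs from compound 2 at the carbonyl carbon: isopropylamino in place of propyl on a carbonyl carbon. Among the compounds with values here, no measured step covers this change. Within the data shown here, the one step recorded, the thiophen-2-yl for furan-2-yl exchange on the saturated ring carbon, sits elsewhere on the core and says nothing about the carbonyl substituent. With both measured values close to zero, and nothing in the data pointing upward, the expected step of a number 1 percentage points higher from compound 2 to compound 3 (within the scatter) is none beyond the scatter. Compound 3 is therefore estimated at 3% in this assay, with a range from -8% to 15%.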

Compound 3, a percentage reported as inhibition, at one concentration (the size of the read-out at that concentration, not a potency): 2%
Estimate against measurement, compound 3: 1 percentage points above, within the range that was stated.
By their numbers in this assay, from the lowest: compounds 1, 2 and 3 (each within the scatter of the next).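

Isopropylamino in place of propyl on a carbonyl carbon, the same difference as propylcarbonyl to isopropylcarbamoyl, gives in this assay no change at the digits printed from compound 2 to compound 3 (within the scatter). Going by these compounds alone, this is the first reading at this position, since the earlier step concerned only the group on the saturated ring carbon: here a nitrogen and a hydrogen-bond donor enter on the carbonyl carbon, and the ketone and the amide read level, with compound 3 at 2%. No measurement is at hand that would explain this reading.

All three compounds sit near the bottom of the scale at the one concentration tested, so the result shows no rise with this amide but cannot separate the two groups any further, and it says nothing about amides in general. On these data alone, whether a longer alkyl chain or a benzyl group on the amide nitrogen, or an ethoxy group on the carbonyl carbon, would move the number in this assay beyond the scatter stays open.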